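Adding a methoxy to compound 2

The source may hold more compounds than are shown below. What is called first, only, known or untested is meant among the compounds shown, and "the series" means these compounds.

In a functional assay on B16-F10 cells (Mus musculus) for inhibition, read by colorimetric assay and MTT assay, with a stated time of 72 h (on this read-out lower numbers stand for stronger inhibition and higher numbers for weaker inhibition), compound 1 (`CCCCCCOc1ncc(-c2ccccc2OC)n1C`) reads 38000 nM and compound 3 (`C=CCCCCOc1ncc(-c2cc(Cl)ccc2OC)n1C`) reads 29000 nM in the same test, two values within the usual scatter of each other. Compound 2 (`C=CCCCCOc1ncc(-c2ccccc2OC)n1C`) stands as "not determined" (no result reported) in the same test, so it has no number to stand on. Compound 4 (`C=CCCCCOc1ncc(-c2cccc(OC)c2OC)n1C`) has not yet been measured. The change (methoxy in place of hydrogen on an aromatic carbon) is methoxy in place of hydrogen on an aromatic carbon. In this assay no step beyond the scatter is expected, since compound 1 at 38000 nM and compound 3 at 29000 nM stand close together. For compound 4 the estimated value is 30000 nM with an expected range from 12000 nM to 70000 nM on this read-out.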

Compound 4, half-maximal inhibitory concentration: 27000 nM
For compound 4 the middle estimate is 1.1-fold (0.05 log units) above the measured one; the range from low to high includes it.
By their numbers in this assay, from the lowest: compounds 4, 3 and 1 (each within the scatter of the next).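

For the compounds shown here, compound 2 has no number to set against compound 4, so no step between them can be read. The compounds shown leave open what methoxy in place of hydrogen changes in this assay for this shared core. No evidence here bears on the result.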